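Imidazolylbutyl for pyrrolylpropyl on a shared maleimide core

The compounds below may be only part of what the source reports. "The series", "measured", "known", "first", "only" and "open" are said of these compounds alone.

Measured compounds:
Compound 1, `Cn1cc(C2=C(c3nn(CCn4ccnc4)c4ncccc34)C(=O)NC2=O)c2ccccc21` — > 100000 nM (a limit)
Compound 2, `Cn1cc(C2=C(c3nn(CCCn4cccc4)c4ncccc34)C(=O)N(c3ccccc3)C2=O)c2ccccc21` — > 100000 nM (a limit)
Compound 3, `COc1ccc(N2C(=O)C(c3cn(C)c4ccccc34)=C(c3nn(CCCN4CCCCC4)c4ncccc34)C2=O)cc1` — 3340 nM

Of the compounds shown here, three have been tested in a functional assay on ECa-109 cells (Homo sapiens) for antiproliferative activity, read by MTT assay, with a stated time of 48 h; a higher number here means a weaker inhibitor, a lower number a stronger inhibitor. For compound 1 the result is only a limit of the assay, > 100000 nM. For compound 2 the result is likewise a limit, > 100000 nM, so no number is known for it; it stands at the limit of > 100000 nM in this assay, at which 2 of the 3 values shown sit. Compound 3 alone gives a number, 3340 nM. Within the data shown here, compound 2 and compound 3 differ in more than one place, so their two values show only that compound 3 registers where compound 2 does not.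

Compound 4, `Cn1cc(C2=C(c3nn(CCCCn4ccnc4)c4ncccc34)C(=O)N(c3ccccc3)C2=O)c2ccccc21`, has not yet been measured. Its difference from compound 2 is (1H-imidazol-1-yl)methyl in place of 1H-pyrrol-1-yl on a saturated chain carbon, three bonds along the chain from an aromatic nitrogen. Since compound 2 carries only a limit, no measured step can be read off for this change. Compound 1 also carries an imidazolyl chain and also sits at the limit, which gives little reason to expect a large gain. The expected step from compound 2 to compound 4 in this assay is an at least 1.4-fold lower number from compound 2 to compound 4 (0.15 log units; that floor lies within the scatter), most likely within the scatter or leaving compound 4 at the limit. Compound 4 is therefore estimated at 70000 nM, with a range from 15000 nM to 300000 nM.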

Compound 4, half-maximal inhibitory concentration: 7540 nM
Beside the measured number, compound 4's estimate is 9.3-fold (0.97 log units) above it, outside the stated range (below it).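

Replacing 3-(1H-pyrrol-1-yl)propyl with 4-(1H-imidazol-1-yl)butyl brings this chain position from the limit to a measurable value in this assay and gives an at least 13-fold lower number from compound 2 to compound 4 (1.12 log units; beyond the scatter), so the end of this chain can decide whether a compound on the shared core registers at all. As far as these compounds go, the step is only a floor and its true size is unknown, because the starting point is a limit rather than a number: the limit of > 100000 nM in this assay, at which 2 of the 4 values shown sit. Compound 1 also carries an imidazolyl chain and its result of > 100000 nM is a limit, but it differs from compound 4 in more than one place, so it says nothing about this change.

From the compounds shown here alone, whether the gain follows the imidazole ring or the longer chain stays open, as the change alters both at once: a 3-(1H-imidazol-1-yl)propyl chain or a 4-(1H-pyrrol-1-yl)butyl chain would separate the two. Also open, going by these compounds, is how a morpholine or a dimethylamino group at the end of the butyl chain, or a still longer chain carrying the imidazole, would read in this assay on this core.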